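A few compounds are considered here, and "the series" means these few. Any claim that something is new, unique, unknown or untested is made for them only; others in the source may bear on it.

Measured in a functional assay on DLD-1 cells (Homo sapiens) for antiproliferative activity, read by CellTiter-Glo, with a stated time of 72 h; on this read-out higher numbers stand for weaker inhibition and lower numbers for stronger inhibition:
- Compound 1 `CC1CCN(C2CCN(S(=O)(=O)c3ccc(Cl)nc3)CC2)CC1`: 3700 nM
- Compound 2 `CC1CCN(C2CCN(S(=O)(=O)c3cccc(Cl)c3)CC2)CC1`: > 5000 nM

In this assay compound 2 reads > 5000 nM, which is a limit of the assay and not a number. Compound 3 `Cc1nc(Cl)sc1S(=O)(=O)N1CCC(N2CCC(C)CC2)CC1` carries 2-chloro-4-methyl-1,3-thiazol-5-yl in place of 3-chlorophenyl on a sulfonyl sulfur. Going by the values given here, only one measured step bears on this, as it also swaps the group at that place: an at least 1.3-fold higher number from compound 1 to compound 2 (0.13 log units; that floor lies within the scatter). That step offers no evidence of a large effect from such a swap, so no shift beyond the scatter is expected in this assay, in either direction. The expected step is an at least 1.1-fold lower number from compound 2 to compound 3 (0.04 log units; that floor lies within the scatter). Compound 3 is estimated at 4500 nM, with an expected range of 1800 nM to 9000 nM.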

Compound 3, half-maximal inhibitory concentration: 1.6 nM
Beside the measured number, compound 3's estimate is 2800-fold (3.45 log units) above it; measured number below the stated range.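

Until now, changing the aromatic group on the sulfonyl sulfur had shown no step beyond the scatter, but this change shows that the same place can shift activity very strongly in this assay. Putting 2-chloro-4-methyl-1,3-thiazol-5-yl there gives an at least 3100-fold lower number from compound 2 to compound 3 (3.49 log units; beyond the scatter) and a 2300-fold lower number from compound 1 to compound 3 (3.36 log units; beyond the scatter). The first of these steps is only a floor because compound 2 stands at a limit of the assay and not at a number: the limit of > 5000 nM in this assay, at which 1 of the 3 values shown sits.

The entering group differs from both groups it replaces in several ways at once, with a five-membered ring, two hetero atoms and a methyl, and the compounds shown cannot tell which of these features matters. Also open, going by these compounds, is how a thiazole without the methyl, or one carrying an amine in place of the chlorine, would read in this assay.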